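A few compounds are considered here, and "the series" means these few. Any claim that something is new, unique, unknown or untested is made for them only; others in the source may bear on it.

Two close relatives of a shared core have been tested in an assay on CHO cells for displacement of a labelled ligand from adenosine receptor A1 (Homo sapiens), read by scintillation counting, tested at 10 uM; a higher number here means more inhibition at the concentration tested (going by the name of the read-out), a lower number less inhibition. Compound 1 `Cc1csc(N)c1C(=O)c1ccc(Cl)cc1` gives 1%, and compound 2 `CC(C)(C)Cc1c(-c2ccc(F)cc2F)sc(N)c1C(=O)c1ccc(Cl)cc1` gives 1%; these two values lie within the usual scatter of each other, so neither stands apart. Compound 3 `CC(C)(C)Cc1c(-c2ccco2)sc(N)c1C(=O)c1ccc(Cl)cc1` has not yet been tested. It differs from compound 2 in one place: furan-2-yl in place of 2,4-difluorophenyl on an aromatic carbon. Among the measured compounds shown here, no measured step between neighbouring compounds is available, and compound 2 sits at 1%, so the expected step of a number 1 percentage points higher from compound 2 to compound 3 (within the scatter) is none beyond the scatter. Compound 3 is expected to give 2%, with a range from 0% to 12%.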

Compound 3, a percentage reported as inhibition, at one concentration (the size of the read-out at that concentration, not a potency): 1%
Compound 3: the middle estimate sits 1 percentage points above what was measured, within the range that was stated.
By their numbers in this assay, from the lowest: compounds 1, 2 and 3 (each within the scatter of the next).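

In this assay the step of no change at the digits printed from compound 2 to compound 3 (within the scatter) comes with furan-2-yl in place of 2,4-difluorophenyl on the aromatic carbon next to the ring sulfur. Among the compounds shown here, this is the first single-place comparison: at this position, a five-membered aromatic ring with a hydrogen-bond acceptor and a six-membered aromatic ring of carbon only read alike at the one concentration tested. No measurement offered here accounts for this result. As far as these compounds go, what an amine or a carboxylic acid at this position would give in this assay remains open, as does whether any group here can lift the read-out.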